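The compounds below may be only part of what the source reports. "The series", "measured", "known", "first", "only" and "open" are said of these compounds alone.

Measured compounds:
- compound 1, `O=C1Nc2c(Cl)cccc2/C1=C1/Nc2ccccc2C1=O`, > 100000 nM
- compound 2, `O=C1Nc2ccccc2/C1=C1/Cc2ccccc2C1=O`, 52600 nM
- compound 3, `O=C1NC(=S)N/C1=C1\C(=O)Nc2ccccc21`, 60200 nM

Three compounds have numbers in a functional assay on LoVo cells (Homo sapiens) for antiproliferative activity, read by MTT assay, with a stated time of 72 h; on this read-out lower numbers stand for stronger inhibition and higher numbers for weaker inhibition. Among the measured compounds shown here, compound 1 gives only a limit of the assay, > 100000 nM, not a number; it is the one value that sits at the limit of > 100000 nM in this assay, at which 1 of the 3 values shown sits. Compound 2 gives 52600 nM. Compound 3 gives 60200 nM, the highest of the two numbers, though its gap to compound 2 lies within the scatter of repeated measurements, so no order between the two can be claimed.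

Compound 4, `O=C1NC(=S)N/C1=C1\C(=O)Nc2c(Br)cccc21`, has not yet been measured in this assay. It differs from compound 3 in one place: bromo in place of hydrogen on an aromatic carbon. For the measured compounds named here, no measured pair shows what such a change does on this core, so nothing known here gives a direction. The expectation is a step from compound 3 to compound 4 of about a 1.3-fold lower number from compound 3 to compound 4 (0.13 log units; within the scatter), which is no more than the scatter itself. Compound 4 is therefore estimated at 45000 nM, within a range from 15000 nM to 150000 nM.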

Compound 4, half-maximal inhibitory concentration: 37000 nM
The estimate for compound 4 lay 1.2-fold (0.09 log units) above the measured number; measured number inside the range.
By their numbers in this assay, from the lowest: compounds 4, 2 and 3 (each within the scatter of the next). At a limit, above all of these: compound 1.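

In this assay, among the compounds shown here, the step gives the first reading of a change on this core, bromo in place of hydrogen on an aromatic carbon, ortho to a fused ring and meta to a fused ring: a 1.6-fold lower number from compound 3 to compound 4 (0.21 log units; within the scatter). This step lies within the scatter, so the position carries a bromo without any change in the read-out that could be claimed. Compound 1 alone remains at a limit of the assay, so the step is read between two true numbers: the limit of > 100000 nM in this assay, at which 1 of the 4 values shown sits.

Going by these compounds, whether another group at this position, such as an amine, a methoxy group or a carboxylic acid, would move the number beyond the scatter stays open. The compounds shown also leave open what bromo does at other places on this aromatic ring, or on the core of compound 2.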